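Carboxy for Hydroxy on Two Quinoline Amide Cores

The compounds below may be only part of what the source reports. "The series", "measured", "known", "first", "only" and "open" are said of these compounds alone.

Of the compounds shown here, three have been measured. Compound 1 `Cc1c(C(=O)Nc2c(F)cc(-c3cccc(F)c3)cc2F)nc2ccc(F)cc2c1O` and compound 3 `Cc1c(C(=O)Nc2c(F)cc(-c3cccc(F)c3)cc2F)nc2ccc(F)cc2c1C(=O)O` share one core, and compound 2 `COc1ccc2nc(C(=O)Nc3ccc(-c4ccccc4)cc3)c(C)c(O)c2c1` stands on a second core; the difference between the two cores is not broken down here. In a functional assay on A-375 cells (Homo sapiens) for antiproliferative activity, read by MTT assay, with a stated time of 24 h, tested at 0.41 ug/mL (on this read-out lower numbers stand for a weaker effect and higher numbers for a stronger effect at the one concentration tested), compound 1 gives 0.86%, compound 3 gives 3.02% and compound 2 gives 7.62%. All three numbers lie within the usual scatter of one another, so no order among them can be read from these data.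

Going by the values given here, the one change that is measured in the set is carboxy in place of hydroxy on an aromatic carbon, which in this assay made a step of a number 2.2 percentage points higher from compound 1 to compound 3 (within the scatter). The unmeasured compound 4 `COc1ccc2nc(C(=O)Nc3ccc(-c4ccccc4)cc3)c(C)c(C(=O)O)c2c1` is related to compound 2 by the same change, (carboxy in place of hydroxy on an aromatic carbon), made at the same place on the core. Since the earlier step from compound 1 to compound 3 stayed within the scatter, the step from compound 2 to compound 4 in this assay is expected to be small as well, and the expectation is a number 1.4 percentage points higher from compound 2 to compound 4 (within the scatter), resting on the step of a number 2.2 percentage points higher from compound 1 to compound 3 (within the scatter) seen with the first core. Compound 4 is therefore estimated to give 9% in this assay, with an expected range from 1% to 18%. Whether the second core answers the change in the same way as the first is not known from one example.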

Compound 4, a percentage reported as inhibition, at one concentration (the size of the read-out at that concentration, not a potency): 11.3%
Estimate against measurement, compound 4: 2.3 percentage points below; low and high end bracket the measured number.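

In this assay, carboxy in place of hydroxy on an aromatic carbon gives a number 3.7 percentage points higher from compound 2 to compound 4 (within the scatter), so the step on the second core is again a small one. Set beside the step on the first core, the change reads alike on the two cores: the same change on two cores in this assay, a number 2.2 percentage points higher (within the scatter) from compound 1 to compound 3 and a number 3.7 percentage points higher (within the scatter) from compound 2 to compound 4, 1.5 percentage points apart, within the scatter of two such steps. This shows that, for these two pairs, the change carried from one core to the other without a visible difference in its size, but it does not show that the change raises the read-out on either core, since each step lies within the scatter, and two pairs at one concentration in one cell assay say nothing about a third core or about other read-outs.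

The compounds shown leave open how other groups on that same aromatic carbon, such as an amine, a methyl ester or a primary amide, would compare with hydroxy and carboxy on either core. They also leave open which of the several differences between the two cores, among them the fluorine atoms and the methoxy group, would matter for this change, if any of them does.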